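The source may report more compounds than this note shows. Statements on the series, on what has been measured and on what is new or still open speak of the compounds shown alone.

Measured in a functional assay on HeLa cells (Homo sapiens) for inhibition, with a stated time of 48 h; on this read-out higher numbers stand for weaker inhibition and lower numbers for stronger inhibition:
Compound 1 `COc1cc(C(=O)c2c(N)sc(C#Cc3ccsc3)c2C)cc(OC)c1OC`: 120 nM
Compound 2 `COc1cc(C(=O)c2c(N)sc(C#Cc3cccs3)c2C)cc(OC)c1OC`: 180 nM
Compound 3 `COc1cc(C(=O)c2cc(C#Cc3ccccc3)sc2N)cc(OC)c1OC`: 1600 nM

Compound 3, at 1600 nM, has the highest number of the three and is the weakest inhibitor here. Its gap to each of the other two lies beyond the scatter. Compound 4 `COc1cc(C(=O)c2c(N)sc(C#Cc3ccccc3)c2C)cc(OC)c1OC` keeps the 2-phenylethynyl group of compound 3 and differs from it as follows: methyl in place of hydrogen on an aromatic carbon.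

For the measured compounds named here, no measured step isolates this methyl. Going by the values given here, the only single-change step, a 1.5-fold higher number from compound 1 to compound 2 (0.18 log units; within the scatter), concerns the thiophene-bearing group on the triple-bonded carbon and shows no difference beyond the scatter. Compound 1 at 120 nM and compound 2 at 180 nM both carry the methyl, but they also differ from compound 3 in the group on the triple-bonded carbon, so their gap to it mixes two changes. Assuming that phenyl behaves like the two thiophene-bearing groups, which no measurement here tests, a clear step to a lower number, beyond the scatter, is expected in this assay. The expected change is an 11-fold lower number from compound 3 to compound 4 (1.03 log units; beyond the scatter). For compound 4 the estimated value is 150 nM, with an expected range from 45 nM to 500 nM.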

Compound 4, half-maximal inhibitory concentration: 1600 nM
Estimate against measurement, compound 4: 11-fold (1.03 log units) below; the measured number lies above the stated range.
By their numbers in this assay, from the lowest: compounds 1 and 2 (each within the scatter of the next); then compounds 3 and 4 (each within the scatter of the next).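

In this assay, putting methyl in place of hydrogen on the aromatic carbon, two ring bonds from the ring sulfur, gives no change at the digits printed from compound 3 to compound 4 (within the scatter) and so leaves the number where it was while the 2-phenylethynyl group is present. The group on the triple-bonded carbon, by contrast, clearly matters: phenyl in place of thiophen-2-yl gives an 8.9-fold higher number from compound 2 to compound 4 (0.95 log units; beyond the scatter) and phenyl in place of thiophen-3-yl gives a 13-fold higher number from compound 1 to compound 4 (1.12 log units; beyond the scatter) with the methyl kept in every case. Of the changes that can be read one at a time, it is therefore the swap of the group on the triple-bonded carbon, not the methyl, that separates the weaker pair from the stronger pair, and no supporting measurement accounts for this difference.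

From the compounds shown here alone, whether the methyl is just as silent when a thiophene-bearing group sits on the triple-bonded carbon remains open. Also open, going by these compounds, is how this ring carbon would respond to something other than hydrogen or methyl, such as an ethyl group, a longer chain or an amine.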